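Cyclopropane Diesters with Trimethoxyphenyl: Amide Variation Notes

The source may hold more compounds than are shown below. What is called first, only, known or untested is meant among the compounds shown, and "the series" means these compounds.

Measured compounds:
compound 1, `CCOC(=O)[C@]1(C(=O)NCc2ccc(C)cc2)C[C@H]1c1cc(OC)c(OC)c(OC)c1`, 13300 nM
compound 2, `CCOC(=O)[C@@]1(C(=O)Nc2ccccc2)C[C@H]1c1cc(OC)c(OC)c(OC)c1`, 65900 nM

Two compounds have been run in a functional assay on A549 cells (Homo sapiens) for cytotoxicity, read by MTT assay, with a stated time of 48 h; a lower number here means a stronger inhibitor, a higher number a weaker inhibitor. Compound 2 stands at the weaker end of the two numbers, with 65900 nM, and compound 1, which carries the 4-methylbenzyl amide, gives 13300 nM; the two values lie apart by more than the usual scatter, with compound 1 the stronger of the pair.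

Compound 3 is `CCOC(=O)[C@@]1(C(=O)NCc2ccc(C)cc2)C[C@H]1c1cc(OC)c(OC)c(OC)c1`. It is obtained from compound 2 by a single change, (4-methylbenzyl in place of phenyl on an amide-type nitrogen). Among the measured compounds shown here, compound 1 shows what the 4-methylbenzyl amide can deliver in this assay, though compound 1 and compound 3 are not single-change neighbours, so no step between them is available. The expectation is that the step of a 4.1-fold lower number from compound 2 to compound 3 (0.61 log units; beyond the scatter) will be towards a lower number and beyond the scatter, resting on the gap between compound 2 and compound 1, which share only the amide substituent difference among other features. Compound 3 is therefore estimated at 16000 nM, with a likely range from 5000 nM to 50000 nM.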

Compound 3, half-maximal inhibitory concentration: 17100 nM
Estimate against measurement, compound 3: 1.1-fold (0.03 log units) below; the measured number falls inside the stated range.
By their numbers in this assay, from the lowest: compounds 1 and 3 (each within the scatter of the next); then compound 2.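

In this assay, the amide nitrogen now has a single-change comparison: 4-methylbenzyl in place of phenyl gives a 3.9-fold lower number from compound 2 to compound 3 (0.59 log units; beyond the scatter), so this substituent alone shifts the number by more than the scatter, which the earlier pair could not show as it also differed in configuration. The stereocentre at the saturated ring carbon, drawn R in compound 1 and S in compound 3, shows no difference that can be read in this assay, with a 1.3-fold higher number from compound 1 to compound 3 (0.11 log units; within the scatter). This reading applies to the 4-methylbenzyl amide only, and no other structural change enters the comparison: the fact that compounds 1 and 3 differ only in the configuration as drawn

On these data alone, whether the configuration is equally without consequence for the anilino amide remains open, as does how the step divides between the benzyl link and the ring methyl. Also open, as far as these compounds go, is how an unsubstituted benzyl or a longer alkyl chain on the amide nitrogen, or a carboxylic acid in place of the ethyl ester, would read in this assay.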